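Saturating the Fused Ring of a Glucagon Receptor Antagonist

The source may report more compounds than this note shows. Statements on the series, on what has been measured and on what is new or still open speak of the compounds shown alone.

Measured compounds:
Compound 1, `CCCC(Oc1ccc(-n2cc3ccccc3n2)cc1)c1ccc(C(=O)NCCC(=O)O)cc1`, gives 2000 nM.
Compound 2, `CCC(Oc1ccc(-n2cc(C(F)(F)F)cn2)cc1)c1ccc(C(=O)NCCC(=O)O)cc1`, is reported only as a limit, > 22000 nM.

In a functional assay on cells for antagonist activity at Glucagon receptor (Homo sapiens), read by cAMP accumulation, in the presence of a further agent that is not named here (on this read-out lower numbers stand for stronger inhibition and higher numbers for weaker inhibition), compound 1 carries the only actual number shown. Compound 2 sits at a limit, which means the assay could not assign it a number. What is known of the measured compounds beyond this is the limit of > 22000 nM in this assay, at which 1 of the 2 values shown sits, and it concerns compound 2 alone.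

Compound 3, `CCCC(Oc1ccc(-n2cc3c(n2)CCCC3)cc1)c1ccc(C(=O)NCCC(=O)O)cc1`, has not been measured. It differs from compound 1 by a group of 9 heavy atoms (7 carbon, 2 nitrogen; one five-membered aromatic ring with 2 hetero atoms, one six-membered non-aromatic ring of carbon only) in place of a group of 9 heavy atoms (7 carbon, 2 nitrogen; one five-membered aromatic ring with 2 hetero atoms, one six-membered aromatic ring of carbon only), on an aromatic carbon: a group of 9 heavy atoms (7 carbon, 2 nitrogen; one five-membered aromatic ring with 2 hetero atoms, one six-membered non-aromatic ring of carbon only) in place of a group of 9 heavy atoms (7 carbon, 2 nitrogen; one five-membered aromatic ring with 2 hetero atoms, one six-membered aromatic ring of carbon only), on an aromatic carbon, para to a large group. For the measured compounds named here, no pair of measured compounds differs at this one place, so the size of the step rests on expectation alone. A modest weakening is expected, about a 2.3-fold higher number from compound 1 to compound 3 (0.35 log units; beyond the scatter), only a little beyond the usual scatter. Compound 3 is estimated at 4500 nM, with a likely range from 1500 nM to 15000 nM.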

Compound 3, antagonist equilibrium constant: 4200 nM
Beside the measured number, compound 3's estimate is 1.1-fold (0.03 log units) above it; low and high end bracket the measured number.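

In this assay, exchanging the 2H-indazol-2-yl group for its counterpart with a non-aromatic six-membered carbon ring gives a 2.1-fold higher number from compound 1 to compound 3 (0.32 log units; beyond the scatter) and so a modest step that lies beyond the scatter. Both groups have the same heavy-atom count and the same five-membered aromatic ring, so the six-membered ring's aromaticity is the one thing that differs here, and compound 3 still gives 4200 nM and not a limit, showing that a measurable number does not depend on that ring being aromatic. Nothing measured among these compounds accounts for the size of this step.

For the compounds shown here, this single pair cannot show whether the same modest step would appear on a different core or with a different chain in place of the one shared by compound 1 and compound 3. It also leaves open how the non-aromatic ring would respond to added groups such as a methyl, a hydroxyl or a fluorine, or to an oxygen or an amine nitrogen in place of one of its carbons.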